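A few compounds are considered here, and "the series" means these few. Any claim that something is new, unique, unknown or untested is made for them only; others in the source may bear on it.

Measured so far in a functional assay on the whole organism for antagonist activity, with Mus musculus as the target; on this read-out lower numbers stand for an effect already at smaller amounts and higher numbers for an effect only at larger amounts of compound:
- compound 1 `CCC(=O)N(c1cccc(C)c1)C1CCCC1N(C)C`: 1 mg/kg; 1 mg/kg (2 entries)
- compound 2 `CCC(=O)N(c1cccc(OC)c1)C1CCCC1N(C)C`: 4 mg/kg
- compound 3 `CCC(=O)N(c1cccc(Cl)c1)C1CCCC1N(C)C`: 0.2 mg/kg

Compound 3 gives the lowest number of the series in this assay. Its nearest neighbour by value is compound 2, and the step of a 20-fold lower number from compound 2 to compound 3 (1.30 log units; beyond the scatter) is large and well beyond the scatter. For the measured compounds named here, compound 1 gives two entries, both higher than the number for compound 3, but no step between these two is worked out here, so only the two values themselves are noted.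

Compound 4 `CCC(=O)N(c1ccc(F)c(Cl)c1)C1CCCC1N(C)C` is the next compound to be measured in this assay. Relative to compound 3 the change is fluoro in place of hydrogen on an aromatic carbon.

Going by the values given here, no measured step concerns a fluoro entering in place of hydrogen; the only step worked out, methoxy to chloro, changes a different group and gives no direct guide. With nothing to point either way, a step within the scatter is expected from compound 3 to compound 4, namely no change at the digits printed from compound 3 to compound 4 (within the scatter). Compound 4 is therefore estimated at 0.2 mg/kg in this assay, with a range from 0.08 mg/kg to 0.5 mg/kg.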

Compound 4, dose for half-maximal effect: 2 mg/kg
Compound 4: middle estimate off by 10-fold (1.00 log units), on the low side; the measured number lies above the stated range.
By their numbers in this assay, from the lowest: compound 3; then compounds 4 and 2 (each within the scatter of the next).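

In this assay, for the compounds shown here, this is the first step at the ring carbon para to a large group and ortho to the chloro group; the earlier step, methoxy to chloro, concerned a different group. Here a fluoro in place of hydrogen, a single heavy atom, gives a 10-fold higher number from compound 3 to compound 4 (1.00 log units; beyond the scatter), so this position is not neutral to substitution, at least with the chloro group present. No available measurement explains the direction or size of this step.

As far as these compounds go, it remains open whether the higher number is specific to fluoro or would also follow from a hydroxyl, an amino group or a methyl at this carbon. Also open, from the compounds shown here alone, is whether fluoro has the same effect when the chloro group is replaced by the methyl of compound 1 or the methoxy of compound 2.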